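Three Measured Compounds and a Fourth to Predict

A few compounds are considered here, and "the series" means these few. Any claim that something is new, unique, unknown or untested is made for them only; others in the source may bear on it.

Measured compounds and their values:
compound 1, `CC(C)=CCC1Cc2c(OCc3ccccc3)cc(=O)n(CCCO)c2CC1(C)C`, gives 11.1% in a functional assay on PANC-1 cells (Homo sapiens) for inhibition, read by MTT assay, with a stated time of 24 h, tested at 10 uM; a lower number here means less inhibition, a higher number more inhibition at the concentration tested (going by the name of the read-out);
compound 2, `CC(C)=CCC/C(C)=C/COc1cc(=O)n(CCCO)c2c1CC(CC=C(C)C)C(C)(C)C2`, gives 18.4% in this assay;
compound 3, `CC(C)=CCC1Cc2c(OCCCNS(=O)(=O)c3ccc(Cl)cc3)cc(=O)n(CCCO)c2CC1(C)C`, gives 9.8% in this assay.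

All three numbers sit close together. Among the compounds with values here, the one step between measured compounds that differ in a single place is a number 7.3 percentage points higher from compound 1 to compound 2 (within the scatter), so even that change left the read-out where the scatter of repeated measurements would put it. Compound 3 has the lowest of the three numbers, but its gaps to compound 1 and to compound 2 are both within the scatter, so nothing separates it from the others with any confidence.

Compound 4, `CC(C)=CCC1Cc2c(OCCCNC(=O)c3ccco3)cc(=O)n(CCCO)c2CC1(C)C`, differs from compound 3 in one place: (furan-2-yl)carbonyl in place of (4-chlorophenyl)sulfonyl on an amine nitrogen. Within the data shown here, no measured step concerns this part of the molecule; the only step available, from compound 1 to compound 2, changes a different group and was itself within the scatter. There is therefore no reason drawn from these compounds to expect a shift beyond the scatter in this assay in either direction.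

Compound 4 is accordingly expected to give 12%, with a range from 3% to 22%, which means an expected step of a number 2.2 percentage points higher from compound 3 to compound 4 (within the scatter).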

Compound 4, a percentage reported as inhibition, at one concentration (the size of the read-out at that concentration, not a potency): 4.3%
Beside the measured number, compound 4's estimate is 7.7 percentage points above it; the measured number falls inside the stated range.
By their numbers in this assay, from the lowest: compounds 4, 3, 1 and 2 (each within the scatter of the next, the first and the last beyond it).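

In this assay, within the data shown here, (furan-2-yl)carbonyl in place of (4-chlorophenyl)sulfonyl on the amine nitrogen gives a number 5.5 percentage points lower from compound 3 to compound 4 (within the scatter) and so offers a first reading at this position: this exchange of one group for another, a sulfonyl link and six-membered ring for a carbonyl link and five-membered ring, does not carry the read-out clear of the usual scatter. Among these compounds, the larger exchange on the saturated chain carbon bound to the oxygen behaves differently according to the group replaced, since the 2-(((furan-2-yl)carbonyl)amino)ethyl group gives a number 14.1 percentage points lower from compound 2 to compound 4 (beyond the scatter) when it replaces 2,6-dimethylhepta-1,5-dien-1-yl, the first modest step beyond the scatter in this set, but gives a number 6.8 percentage points lower from compound 1 to compound 4 (within the scatter) when it replaces phenyl. No measurement at hand bears on what lies behind these numbers.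

The compounds shown leave open whether a free amine or a simple acetyl group on that nitrogen would read any differently from the two groups seen there. They also leave open whether a longer chain ending in the same ((furan-2-yl)carbonyl)amino group would change the read-out.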